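A few compounds are considered here, and "the series" means these few. Any claim that something is new, unique, unknown or untested is made for them only; others in the source may bear on it.

Of the compounds shown here, three that share one core have been measured in a functional assay on PC-12 cells (Rattus norvegicus) for cytotoxicity, read by MTT assay, with stated times of 2 h and 24 h, tested at 5 uM; on this read-out lower numbers stand for a weaker effect and higher numbers for a stronger effect at the one concentration tested. Compound 1 `Cc1ccc(-n2nc(-c3ccc(C(F)(F)F)cc3O)nc2-c2ccccc2O)cc1` gives 94.1%, compound 2 `Oc1cc(C(F)(F)F)ccc1-c1nc(-c2ccccc2O)n(-c2ccc(Br)cc2)n1` gives 89.8%, and compound 3 `Oc1cc(C(F)(F)F)ccc1-c1nc(-c2ccccc2O)n(-c2ccccc2F)n1` gives 86.6%. Compound 2 is the second highest of these three numbers, yet its gaps to both others lie within the scatter. The move to compound 4 `COc1ccccc1-n1nc(-c2ccc(C(F)(F)F)cc2O)nc1-c1ccccc1O` is 2-methoxyphenyl in place of 4-bromophenyl on an aromatic nitrogen. Two measured steps also exchange the group on that aromatic nitrogen: a number 7.5 percentage points lower from compound 1 to compound 3 (within the scatter) and a number 3.2 percentage points lower from compound 2 to compound 3 (within the scatter), and neither goes beyond the scatter. The expected step, a number 1.8 percentage points lower from compound 2 to compound 4 (within the scatter), is therefore small and within the scatter. Compound 4 is thus estimated at 88%, with a range from 78% to 96%.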

Compound 4, a percentage reported as activity, at one concentration (the size of the read-out at that concentration, not a potency): 85.6%
Compound 4: the middle estimate sits 2.4 percentage points above what was measured; measured number inside the range.
By their numbers in this assay, from the lowest: compounds 4, 3, 2 and 1 (each within the scatter of the next).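

In this assay the 2-methoxyphenyl group on the aromatic nitrogen gives a number 4.2 percentage points lower from compound 2 to compound 4 (within the scatter) and a number 1 percentage points lower from compound 3 to compound 4 (within the scatter) and also a number 8.5 percentage points lower from compound 1 to compound 4 (within the scatter) so all three steps stay within the scatter. This position has now carried a methoxy-bearing ring alongside the methyl-, bromo- and fluoro-bearing rings, with no step among these four compounds going beyond the scatter. Nothing available explains why these numbers lie so close together.

From the compounds shown here alone, whether an amine, a carboxylic acid or a longer chain on this ring would give a step beyond the scatter remains open. With one concentration tested, the potency of these compounds also remains open.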